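One Halogen Swap on the Compound 1 Scaffold

This account rests on a few compounds, and the source may have more. Where it says the series, first, only, none or still open, it means among the compounds named here.

- Compound 1 `CN(C)C(=O)c1cc2cnc(Nc3ccc(NC(=O)C4(C(=O)Nc5ccc(F)cc5)CC4)cc3)nc2n1C1CCCC1`: 79.9%
- Compound 2 `CN(C)C(=O)c1cc2cnc(Nc3ccc(N)cn3)nc2n1C1CCCC1`: -0.6%

In a functional assay on NCI-H460 cells (Homo sapiens) for inhibition, read by CCK-8 assay, with a stated time of 72 h, tested at 1 uM (on this read-out lower numbers stand for less inhibition of growth and higher numbers for more inhibition of growth at the one concentration tested), compound 1 gives 79.9%, the higher of the two numbers, and the gap down to compound 2 lies beyond the usual scatter. The two compounds differ in more than one place, so that gap says nothing about any single group.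

Compound 3 `CN(C)C(=O)c1cc2cnc(Nc3ccc(NC(=O)C4(C(=O)Nc5ccc(Cl)cc5)CC4)cc3)nc2n1C1CCCC1` keeps the whole of compound 1 apart from one change: chloro in place of fluoro on an aromatic carbon. The change sits para to a large group and turns the 4-fluorophenyl into 4-chlorophenyl. Among the compounds with values here, no measured pair shows this swap, so direct evidence is lacking. In this assay no step beyond the scatter is expected, and neither direction is favoured. The expected change is small, a number 1.9 percentage points lower from compound 1 to compound 3 (within the scatter). For compound 3 the estimated value is 78%, with an expected range of 62% to 92%.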

Compound 3, percent growth inhibition at one concentration: 21.3%
Compound 3: middle estimate off by 56.7 percentage points, on the high side, outside the stated range (below it).
By their numbers in this assay, from the lowest: compound 2; then compound 3; then compound 1.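

This position is far from indifferent. In this assay chloro in place of fluoro on an aromatic carbon gives a number 58.6 percentage points lower from compound 1 to compound 3 (beyond the scatter) even though one halogen atom simply replaces another and the rest of the molecule stays the same. The growth inhibition of compound 1 therefore depends strongly on which halogen sits on this ring, and no measurement here accounts for the drop.

Going by these compounds, whether bromo, methyl or a plain hydrogen on this same carbon would read closer to compound 1 or to compound 3 remains open, so no trend across substituents can be drawn from this single swap. Testing at only one concentration also leaves open how far compound 1 and compound 3 would differ across a full dose range.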